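A few compounds are considered here, and "the series" means these few. Any claim that something is new, unique, unknown or untested is made for them only; others in the source may bear on it.

Working notes on the series.

Compound 1 `Cc1nc(N)c2c(-c3ccccc3)cn([C@@H]3O[C@H](CO)[C@@H](O)[C@H]3O)c2n1` and compound 2 `Cc1nc(N)c2c(-c3cccs3)cn([C@@H]3O[C@H](CO)[C@@H](O)[C@H]3O)c2n1` share one core; compound 3 `COc1ncnc2c1c(-c1cccs1)cn2[C@@H]1O[C@H](CO)[C@@H](O)[C@H]1O` carries a different core, and the difference between the two cores is not broken down here. In a functional assay on CCRF-CEM cells (Homo sapiens), read by MTT assay, with a stated time of 72 h (a higher number here means a weaker inhibitor, a lower number a stronger inhibitor), compound 1 gives > 20000 nM, which is a limit of the assay and not a number. In this assay compound 2 likewise gives > 20000 nM, again a limit rather than a number. In this assay, among the measured compounds shown here, compound 3 gives 90 nM, the only number among the three.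

The change phenyl in place of thiophen-2-yl on an aromatic carbon gives the step that the two limits leave unreadable from compound 2 to compound 1; its size cannot be read because the limit of > 20000 nM in this assay, at which 2 of the 3 values shown sit, leaves both ends open.

Compound 4 `COc1ncnc2c1c(-c1ccccc1)cn2[C@@H]1O[C@H](CO)[C@@H](O)[C@H]1O` is not yet measured. It differs from compound 3 by phenyl in place of thiophen-2-yl on an aromatic carbon, the same change as from compound 2 to compound 1, with the place described in the same words. For the measured compounds named here, since the measured instance of this change is unreadable, the expectation for compound 4 rests on compound 3 alone, whose value of 90 nM is the only number in the set, and on the step from compound 2 to compound 1 not being readable in either direction.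

The step of a 2.2-fold higher number from compound 3 to compound 4 (0.35 log units; beyond the scatter) is therefore expected to be modest, with a wide range allowed. In this assay compound 4 is estimated at 200 nM, most likely between 50 nM and 1200 nM.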

Compound 4, half-maximal inhibitory concentration: > 20000 nM
Compound 4 gave a limit, no number (the forecaster's own chance of this, stated with the estimate: 10%); middle value at least 100-fold (2.00 log units) away from the limit.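

In this assay, on the core of compound 3, phenyl in place of thiophen-2-yl on the aromatic carbon gives an at least 220-fold higher number from compound 3 to compound 4 (2.34 log units; beyond the scatter), so on this core the change separates a compound that returns a number from one that does not. On these data alone, compound 4 gives > 20000 nM, which is a limit of the assay and not a number, so the full size of this step remains unknown. The same change from compound 2 to compound 1 cannot be read, so the series holds one readable instance and no test of whether the step carries from one core to another: the limit of > 20000 nM in this assay, at which 3 of the 4 values shown sit.

Only thiophen-2-yl on the core of compound 3 returns a number here, and the compounds shown do not tell how furan-2-yl, thiophen-3-yl or a short chain such as ethyl would read at the same aromatic carbon. No pair shown differs in the core alone, so what the core contributes with thiophen-2-yl held in place also remains open, as does whether any group on the core of compound 1 would return a number in this assay.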